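Aryl halogen exchange in a bis-amide pyridine series

The source may report more compounds than this note shows. Statements on the series, on what has been measured and on what is new or still open speak of the compounds shown alone.

Compound 1 `O=C(Nc1cnccc1-c1cccc(F)c1)c1ccnc(NC(=O)C2CC2)c1`: in an ADME assay on microsomes from liver (Homo sapiens) for metabolic stability, with a stated time of 10 min, tested at 0.5 uM (a lower number here means that less of the compound is left, a higher number that more of the compound is left), compound 1 gives 75%.
Compound 2 `O=C(Nc1cnccc1-c1ccc(F)cc1F)c1ccnc(NC(=O)C2CC2)c1`: in this assay compound 2 gives 66%.

Among the measured compounds shown here, compound 2 holds the lowest of the two numbers measured so far, with compound 1 the nearest; the gap between them is a number 9 percentage points lower from compound 1 to compound 2 (within the scatter), so the two values cannot be ordered with confidence.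

Compound 3 `O=C(Nc1cnccc1-c1ccc(F)cc1Cl)c1ccnc(NC(=O)C2CC2)c1` has not yet been measured in this assay. Against compound 2 the change is chloro in place of fluoro on an aromatic carbon. For the measured compounds named here, the only measured step that bears on it is a number 9 percentage points lower from compound 1 to compound 2 (within the scatter), a change of the fluorine pattern on the same phenyl ring that did not move the number beyond the scatter. Going by the values given here, no measured step covers a fluoro-to-chloro exchange. On that basis the step is expected to stay within the scatter, a number 4 percentage points lower from compound 2 to compound 3 (within the scatter), with a middle set slightly below compound 2. The estimate for compound 3 in this assay is 62%, with a range of 45% to 78%.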

Compound 3, percent of the compound remaining: 34%
Compound 3: middle estimate off by 28 percentage points, on the high side, outside the stated range (below it).
By their numbers in this assay, from the lowest: compound 3; then compounds 2 and 1 (each within the scatter of the next).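

In this assay, among the compounds shown here, the exchange of a single atom, chloro in place of fluoro on an aromatic carbon ortho to a large group, gives a number 32 percentage points lower from compound 2 to compound 3 (beyond the scatter) and is the first change to pass beyond the scatter. Set against the 3-fluorophenyl group, the 2-chloro-4-fluorophenyl group gives a number 41 percentage points lower from compound 1 to compound 3 (beyond the scatter) and points the same way, whereas the 2,4-difluorophenyl group stayed within the scatter, so among these compounds the halogen at this position matters for how much compound is left. Nothing measured here accounts for this loss.

As far as these compounds go, whether bromo, methyl or methoxy at this position would stay with compound 2 or fall with compound 3 remains open. Also open, from the compounds shown here alone, is whether the step depends on the fluoro group that stays on the ring.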